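The source may report more compounds than this note shows. Statements on the series, on what has been measured and on what is new or still open speak of the compounds shown alone.

Of the compounds shown here, three have been tested in a functional assay on the whole organism for inhibition, with Rattus norvegicus as the target, read by paw edema, with a stated time of 30 min, at a dose of 40 mg/kg by the oral route; a lower number here means a weaker effect, a higher number a stronger effect of the compound at the dose given. Compound 1, `Cc1ccccc1OCC1=NCCO1`, gives 29.5%. Compound 2, `Cc1cccc(OCC2=NCCO2)c1`, gives 44.6%; it has the same atoms as compound 1, joined differently, and the difference between the two cores is not broken down here. Compound 3, `O=[N+]([O-])c1ccccc1OCC1=NCCO1`, gives 35.5%. Within the data shown here, the one step that can be counted is nitro in place of methyl on an aromatic carbon, placed ortho to a group of 7 heavy atoms, and it gave a number 6 percentage points higher from compound 1 to compound 3 (within the scatter).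

Compound 4, `O=[N+]([O-])c1cccc(OCC2=NCCO2)c1`, has not yet been measured. It stands to compound 2 as compound 3 stands to compound 1: nitro in place of methyl on an aromatic carbon, here placed meta to a group of 7 heavy atoms, so the same kind of change but not at the same place. Resting on the step seen from compound 1 to compound 3, a number 6 percentage points higher from compound 1 to compound 3 (within the scatter), the step from compound 2 to compound 4 is expected to be a number 5.4 percentage points higher from compound 2 to compound 4 (within the scatter). Compound 4 is therefore estimated to give 50% in this assay, expected to fall between 35% and 65%.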

Compound 4, a percentage reported as inhibition, in the whole organism at one dose (the size of the read-out at that dose, not a potency): 29.4%
Estimate against measurement, compound 4: 20.6 percentage points above, outside the stated range (below it).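

In this assay, nitro in place of methyl on an aromatic carbon gave a number 15.2 percentage points lower from compound 2 to compound 4 (beyond the scatter), so the change did not have the same result on both cores: the same change on two cores in this assay, a number 6 percentage points higher (within the scatter) from compound 1 to compound 3 and a number 15.2 percentage points lower (beyond the scatter) from compound 2 to compound 4, 21.2 percentage points apart, beyond the scatter of two such steps

This shows that, in this series, the step seen on the core of compound 1 cannot be carried as a fixed amount to the core of compound 2, where the nitro sits meta to a group of 7 heavy atoms. Among these compounds, it does not show why the two steps part: only one pair stands on each core, and the place of the change varies together with the core, so neither can be singled out.

The compounds shown carry only methyl and nitro on the aromatic ring, so it stays open how chlorine, methoxy or an amine would read on either core. As far as these compounds go, it also stays open whether the two steps would remain this far apart at another dose or another time.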